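Removing the methoxy from compound 3 in the series

The source may hold more compounds than are shown below. What is called first, only, known or untested is meant among the compounds shown, and "the series" means these compounds.

In a functional assay on SGC-7901 cells (Homo sapiens) for antiproliferative activity, read by MTT assay, with a stated time of 72 h (on this read-out higher numbers stand for weaker inhibition and lower numbers for stronger inhibition), compound 1 `COc1cc(-n2cnc3ccc(-c4cccc(N)c4)cc32)cc(OC)c1OC` gives 21 nM, and compound 2 `COc1cc(-n2cnc3ccc(-c4ccc([N+](=O)[O-])cc4)cc32)cc(OC)c1OC` gives 79 nM; the step of a 3.8-fold higher number from compound 1 to compound 2 (0.58 log units; beyond the scatter) separates them. Compound 3 `COc1ccccc1-c1ccc2ncn(-c3cc(OC)c(OC)c(OC)c3)c2c1` gives 5050 nM and stands highest of the three numbers: its nearest neighbour is compound 2, through a 64-fold higher number from compound 2 to compound 3 (1.81 log units; beyond the scatter), and its furthest is compound 1, through a 240-fold higher number from compound 1 to compound 3 (2.38 log units; beyond the scatter). Both of these steps are large, so the 2-methoxyphenyl of compound 3 is associated with the weakest inhibition seen so far.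

Compound 4 `COc1cc(-n2cnc3ccc(-c4ccccc4)cc32)cc(OC)c1OC` is not yet measured. The change from compound 3 is hydrogen in place of methoxy on an aromatic carbon. Going by the values given here, no measured step removes a methoxy, so the two steps into compound 3 bear only indirectly: they show that a different group on this phenyl gives far lower numbers, and they bound how far a lower number could plausibly go. A sizeable drop is expected. Accordingly a step of a 13-fold lower number from compound 3 to compound 4 (1.10 log units; beyond the scatter) is estimated. For compound 4 the expected value is 400 nM, with a range from 60 nM to 3000 nM.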

Compound 4, half-maximal inhibitory concentration: 290 nM
Compound 4: the middle estimate sits 1.4-fold (0.14 log units) above what was measured, within the range that was stated.
By their numbers in this assay, from the lowest: compound 1; then compound 2; then compound 4; then compound 3.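

In this assay, taking away the methoxy ortho to a large group produces a large step (a 17-fold lower number from compound 3 to compound 4 (1.24 log units; beyond the scatter)), so the high number belongs to that methoxy and not to the phenyl that carries it. The plain phenyl also gives a reference for the other groups: hydrogen in place of nitro is a modest step (a 3.7-fold higher number from compound 2 to compound 4 (0.56 log units; beyond the scatter)) and hydrogen in place of amino is a large one (a 14-fold higher number from compound 1 to compound 4 (1.14 log units; beyond the scatter)), so the 4-nitrophenyl and 3-aminophenyl give lower numbers than phenyl, while the 2-methoxyphenyl goes against that direction. Nothing available explains any of these differences.

The compounds shown leave open whether the high number is particular to methoxy or follows other groups in that place, such as fluorine, hydroxyl or amino. They also leave open how much of the gain from amino and nitro depends on where each sits, which a 4-aminophenyl or a 3-nitrophenyl would address.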